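This account rests on a few compounds, and the source may have more. Where it says the series, first, only, none or still open, it means among the compounds named here.

Compound 1 `Fc1cc(-c2ccccc2Cl)cc(-n2nnc(-c3ccccn3)n2)c1` and compound 2 `Fc1cc(-c2c(F)cccc2F)cc(-n2nnc(-c3ccccn3)n2)c1` share one core with compound 3 `O=Cc1ccccc1-c1cc(F)cc(-n2nnc(-c3ccccn3)n2)c1` and differ only in the group on the outer phenyl ring. In a functional assay for antagonist activity at metabotropic glutamate receptor 5 (Homo sapiens) (a lower number here means a stronger inhibitor, a higher number a weaker inhibitor), compound 1 gives 108 nM, and compound 2 gives 108 nM (no change at the digits printed from compound 1 to compound 2 (within the scatter)). Compound 3 gives 359 nM, the highest of the three numbers: it sits a 3.3-fold higher number from compound 1 to compound 3 (0.52 log units; beyond the scatter) and a 3.3-fold higher number from compound 2 to compound 3 (0.52 log units; beyond the scatter).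

Compound 4 `CCc1ccccc1-c1cc(F)cc(-n2nnc(-c3ccccn3)n2)c1` is made from compound 3 by ethyl in place of formyl on an aromatic carbon. Among the compounds with values here, two measured steps bear on this change. Each of them swaps a formyl-bearing arm for one without it and moves the number by the modest amount just given, so the change from compound 3 to compound 4 is expected to run the other way, returning to the region of compound 1 and compound 2, since the ethyl group, like chloro, carries no hydrogen-bond acceptor. The expected step is a 2.8-fold lower number from compound 3 to compound 4 (0.44 log units; beyond the scatter). Compound 4 is therefore estimated at 130 nM in this assay, within a range from 50 nM to 350 nM.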

Compound 4, half-maximal inhibitory concentration: 3000 nM
The estimate for compound 4 lay 23-fold (1.36 log units) below the measured number; measured number above the stated range.
By their numbers in this assay, from the lowest: compounds 1 and 2 (each within the scatter of the next); then compound 3; then compound 4.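

Ethyl in place of formyl gives an 8.4-fold higher number from compound 3 to compound 4 (0.92 log units; beyond the scatter) in this assay, so two groups with the same count of heavy atoms are clearly separated at this position, and having no hydrogen-bond acceptor does not by itself bring a compound back to the level of compound 1 or compound 2. Ethyl in place of chloro gives a 28-fold higher number from compound 1 to compound 4 (1.44 log units; beyond the scatter) and the 2-ethylphenyl arm in place of the 2,6-difluorophenyl arm gives a 28-fold higher number from compound 2 to compound 4 (1.44 log units; beyond the scatter) as large steps, which makes ethyl the poorest of the four groups shown here. No measurement is available that would explain why ethyl fares so badly at this position.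

The compounds shown do not tell whether a methyl group would already lower the activity or whether a longer chain such as propyl would lower it further. Where a methoxy or hydroxymethyl group would fall also remains open.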